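Working notes: from compound 3 to compound 4

The source may hold more compounds than are shown below. What is called first, only, known or untested is meant among the compounds shown, and "the series" means these compounds.

Values in a functional assay on PC-3 cells (Homo sapiens) for antiproliferative activity, read by MTT assay, with a stated time of 48 h; on this read-out higher numbers stand for weaker inhibition and lower numbers for stronger inhibition:
- compound 1 `COc1ccc(CN(C(=O)Cn2cc(CSc3nc4ccccc4s3)nn2)c2cc(OC)c(OC)c(OC)c2)cc1`: 28500 nM
- compound 2 `COc1ccc(CN(C(=O)Cn2cc(CSC3=NCCS3)nn2)c2cc(OC)c(OC)c(OC)c2)cc1`: 16000 nM
- compound 3 `COc1ccc(CN(C(=O)Cn2cc(CSc3nc4ccccc4o3)nn2)c2cc(OC)c(OC)c(OC)c2)cc1`: 5050 nM

Compound 3 holds the lowest number of the three. The next structure, compound 4 `COc1ccc(CN(C(=O)Cn2cc(CNS(=O)(=O)c3ccc(C)cc3)nn2)c2cc(OC)c(OC)c(OC)c2)cc1`, differs by ((4-methylphenyl)sulfonyl)amino in place of (1,3-benzoxazol-2-yl)sulfanyl on a saturated chain carbon bound to an aromatic carbon. Among the compounds with values here, three measured steps bear on this, all changing only the group on sulfur: a 5.6-fold lower number from compound 1 to compound 3 (0.75 log units; beyond the scatter), a 3.2-fold lower number from compound 2 to compound 3 (0.50 log units; beyond the scatter) and a 1.8-fold lower number from compound 1 to compound 2 (0.25 log units; within the scatter). None of them involves the entering group, so they offer only a rough size. Within the data shown here, both groups that differ from the one in compound 3 gave higher numbers, so a modest rise is expected, namely a 2.4-fold higher number from compound 3 to compound 4 (0.38 log units; beyond the scatter). The estimated value for compound 4 is 12000 nM, with an expected range of 3000 nM to 45000 nM.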

Compound 4, half-maximal inhibitory concentration: 12400 nM
The estimate for compound 4 lay 1.0-fold (0.01 log units) below the measured number; the measured number falls inside the stated range.
By their numbers in this assay, from the lowest: compound 3; then compounds 4, 2 and 1 (each within the scatter of the next, the first and the last beyond it).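

In this assay, ((4-methylphenyl)sulfonyl)amino is the only group shown on this saturated chain carbon with a hydrogen-bond donor and without a sulfur link to the ring, and it gives a 2.5-fold higher number from compound 3 to compound 4 (0.39 log units; beyond the scatter) but also a 2.3-fold lower number from compound 1 to compound 4 (0.36 log units; beyond the scatter), so this position accepts the change without leaving the range of the sulfanyl groups. The step of a 1.3-fold lower number from compound 2 to compound 4 (0.11 log units; within the scatter) puts it level with the non-aromatic five-membered ring group. Nothing measured here accounts for these steps. From the compounds shown here alone, what an amine or a carboxylic acid on this carbon would give remains open, as does whether the sulfonylamino link or the 4-methylphenyl ring carries the step from compound 3.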